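This account rests on a few compounds, and the source may have more. Where it says the series, first, only, none or still open, it means among the compounds named here.

Measured in a functional assay on A2780 cells (Homo sapiens) for cytotoxicity, read by MTT assay, with a stated time of 24 h; a lower number here means a stronger inhibitor, a higher number a weaker inhibitor:

- compound 1 `CCCCC[C@H](CCC[C@@H]1CC=CC(=O)O1)OC`: 14400 nM
- compound 2 `CCCCC[C@@H](C[C@H](O)C[C@@H]1CC=CC(=O)O1)OC`: 35400 nM
- compound 3 `CCCCC[C@@H](C[C@@H](O)C[C@H]1CC=CC(=O)O1)OC`: 33700 nM

Compound 3, at 33700 nM, lies within the scatter of compound 2, and the number for compound 1 is lower than both, beyond the scatter from compound 3. The next compound, compound 4 `CCCCC[C@H](C[C@H](O)C[C@H]1CC=CC(=O)O1)OC`, keeps the same atoms and bonds: the two compounds have the same atoms and bonds and differ only in configuration as drawn: 2 of 3 stereo elements differ; a stereocentre at a saturated chain carbon is drawn S in compound 3 and R in compound 4; a stereocentre at a saturated chain carbon is drawn R in compound 3 and S in compound 4. Among the compounds with values here, only one measured step bears on this change, a 1.1-fold lower number from compound 2 to compound 3 (0.02 log units; within the scatter). It is relevant because of the fact that compounds 2 and 3 differ only in the configuration as drawn, and it stays within the scatter. It is a limited guide, however, since the present change involves two saturated chain carbons and the pairs of stereocentres altered are not the same. In this assay, therefore, no shift beyond the scatter is expected, although the range is kept wide. The expected change is a 1.1-fold lower number from compound 3 to compound 4 (0.05 log units; within the scatter). Compound 4 is estimated at 30000 nM, with an expected range from 14000 nM to 58000 nM.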

Compound 4, half-maximal inhibitory concentration: 44000 nM
Beside the measured number, compound 4's estimate is 1.5-fold (0.17 log units) below it, within the range that was stated.
By their numbers in this assay, from the lowest: compound 1; then compounds 3, 2 and 4 (each within the scatter of the next).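

In this assay, within the data shown here, changing the configuration at two saturated chain carbons gives a 1.3-fold higher number from compound 3 to compound 4 (0.12 log units; within the scatter), so this pair of stereocentres, untested by the earlier compounds, moves the number no further than the scatter. The step of a 1.2-fold higher number from compound 2 to compound 4 (0.09 log units; within the scatter) changes a chain carbon and a ring carbon and also stays within the scatter, as the earlier step from compound 2 to compound 3 did. Compounds 2, 3 and 4 therefore cannot be told apart in this assay, and this comparison rests on a single shared feature: the fact that compounds 3 and 4 differ only in the configuration as drawn

Going by these compounds, each of these pairs differs at two stereocentres at once, so the contribution of any single centre remains unknown, and opposing contributions cannot be ruled out. On these data alone, whether an amine in place of the chain hydroxyl, or a longer chain, would shift the number also stays open.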